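A Second Fluorine on a Sulfoxide Analogue

This account rests on a few compounds, and the source may have more. Where it says the series, first, only, none or still open, it means among the compounds named here.

Of the compounds shown here, three have been measured in an assay on membranes from striatum (strain Sprague-Dawley) for displacement of a labelled ligand from sodium-dependent dopamine transporter (Rattus norvegicus), read by scintillation counting, with a stated time of 120 min; on this read-out lower numbers stand for stronger inhibition and higher numbers for weaker inhibition. Compound 1, `O=C(c1ccc(F)cc1)N1CCC(NCCSC(c2ccc(F)cc2)c2ccc(F)cc2)CC1`, gives 7.04 nM in this assay. Compound 2, `O=C(c1ccc(F)cc1F)N1CCC(NCCSC(c2ccc(F)cc2)c2ccc(F)cc2)CC1`, gives 30 nM. Compound 3, `O=C(c1ccccc1F)N1CCC(NCC[S+]([O-])C(c2ccc(F)cc2)c2ccc(F)cc2)CC1`, gives 604 nM, the highest of the three numbers and well beyond the scatter from both of the others.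

The step from compound 1 to compound 2 is a single change, (fluoro in place of hydrogen on an aromatic carbon), and it moved the read-out by a 4.3-fold higher number from compound 1 to compound 2 (0.63 log units; beyond the scatter). Compound 4, `O=C(c1ccc(F)cc1F)N1CCC(NCC[S+]([O-])C(c2ccc(F)cc2)c2ccc(F)cc2)CC1`, has not yet been measured. It differs from compound 3 by fluoro in place of hydrogen on an aromatic carbon. How the core of compound 3 differs from the core of compound 1 is not broken down here. The two placements of the new fluoro are not word for word the same: in compound 2 it sits ortho to a large group and meta to a fluoro group, whereas in compound 4 it sits meta to a fluoro group and para to a large group, so the change is the same kind of change rather than the same one.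

On that basis the step in this assay is expected to be a 3.6-fold higher number from compound 3 to compound 4 (0.56 log units; beyond the scatter), close in size and direction to the earlier one, because compound 2 showed a 4.3-fold higher number from compound 1 to compound 2 (0.63 log units; beyond the scatter). For compound 4 the estimated value is 2200 nM, with a likely range from 700 nM to 7000 nM.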

Compound 4, inhibition constant: 564 nM
Beside the measured number, compound 4's estimate is 3.9-fold (0.59 log units) above it; measured number outside the range, below it.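

In this assay, the swap from 2-fluorophenyl to 2,4-difluorophenyl on the sulfoxide gave a 1.1-fold lower number from compound 3 to compound 4 (0.03 log units; within the scatter), a step that cannot be told apart from the ordinary spread of repeated measurements. So in this series the size of the fluoro step did not carry over from one core to the other, and the gap between the two steps is real rather than noise: the same change on two cores in this assay, a 4.3-fold higher number (0.63 log units; beyond the scatter) from compound 1 to compound 2 and a 1.1-fold lower number (0.03 log units; within the scatter) from compound 3 to compound 4, 4.6-fold (0.66 log units) apart, beyond the scatter of two such steps What this does not show is the reason for the gap, since the two pairs differ both in their cores and in where the new fluoro stands relative to the other groups, and each core contributes only a single pair, so no general rule about this change can be drawn from them.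

The compounds shown leave open whether a chloro or a methoxy group entering at the same place would also give steps that differ between the two cores. They also leave open how a sulfone in place of the sulfoxide would fit with either result, and whether the fluoro step would then resemble the one on the core of compound 1 or the one on the core of compound 3.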